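Notes on a furan-to-chlorophenyl exchange in a small series

The source may report more compounds than this note shows. Statements on the series, on what has been measured and on what is new or still open speak of the compounds shown alone.

Measured so far:
compound 1, `Cc1ccsc1-c1cc(-c2ccoc2)cc(-c2ccco2)n1`: 5.4% in an assay on isolated protein for inhibition of DNA topoisomerase 1 (Homo sapiens), with a stated time of 30 min, tested at 100 uM; a lower number here means less inhibition, a higher number more inhibition at the concentration tested (going by the name of the read-out)
compound 2, `Cc1ccsc1-c1cc(-c2ccc(Cl)o2)cc(-c2ccco2)n1`: 7.8% in this assay

Both numbers in this assay are small. Within the data shown here, compound 2 and compound 1 are the only pair with a computed step, a number 2.4 percentage points higher from compound 1 to compound 2 (within the scatter), and that step lies within the scatter, so the two compounds are not told apart on these numbers; compound 1 is the nearest and only neighbour of compound 2.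

The next compound, compound 3, `Cc1ccsc1-c1cc(-c2ccc(Cl)o2)cc(-c2cccc(Cl)c2)n1`, differs from compound 2 in one place: 3-chlorophenyl in place of furan-2-yl on an aromatic carbon. Among the measured compounds shown here, no measured step exchanges a furan-2-yl for a 3-chlorophenyl at this position, and the one step on record, a number 2.4 percentage points higher from compound 1 to compound 2 (within the scatter), concerns another position and other groups, so it bears only indirectly on the change. With nothing in the series pointing to a shift beyond the scatter, the expected step of a number 0.8 percentage points lower from compound 2 to compound 3 (within the scatter) is none beyond the scatter. Compound 3 is therefore estimated at 7% in this assay, with a range from 0% to 20%.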

Compound 3, a percentage reported as inhibition, at one concentration (the size of the read-out at that concentration, not a potency): 5.9%
Beside the measured number, compound 3's estimate is 1.1 percentage points above it, and the stated range covers the measured number.
By their numbers in this assay, from the lowest: compounds 1, 3 and 2 (each within the scatter of the next).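

In this assay, among these compounds, putting 3-chlorophenyl in place of furan-2-yl on the aromatic carbon next to the ring nitrogen gives a number 1.9 percentage points lower from compound 2 to compound 3 (within the scatter), the first reading at this position, and it does not tell the two groups apart. This exchange is not a small one on paper: a five-membered aromatic ring with 1 hetero atom and 1 hydrogen-bond acceptor leaves, and a six-membered aromatic ring of carbon only, with a chlorine and 0 hydrogen-bond acceptors, enters, yet the read-out at this one concentration does not separate compound 2 from compound 3. Nothing on hand explains this outcome or connects it to any measured property of either group.

Going by these compounds, whether a different kind of group at this position, such as an amine or a carboxylic acid, would move the number beyond the scatter remains open. Also open, on these data alone, is whether 3-chlorophenyl would read the same with furan-3-yl in place of the 5-chlorofuran-2-yl group, since compound 3 carries this exchange on one background only.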